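Anilide variation in a triazole thioether series

The source may hold more compounds than are shown below. What is called first, only, known or untested is meant among the compounds shown, and "the series" means these compounds.

Compound 1 `Cc1occc1-c1nnc(SCC(=O)Nc2ccc(F)c(Cl)c2)n1Cc1ccco1` gives 1000 nM in a functional assay on CHO cells for antagonist activity at Orexin/Hypocretin receptor type 1 (Homo sapiens), read by FLIPR and calcium flux; on this read-out higher numbers stand for weaker inhibition and lower numbers for stronger inhibition. Compound 2 `Cc1occc1-c1nnc(SCC(=O)Nc2ccc(F)cc2)n1Cc1ccco1` gives only a limit in this assay, namely > 15800 nM. Compound 3 `COc1ccccc1NC(=O)CSc1nnc(-c2ccoc2C)n1Cc1ccco1` likewise gives only a limit in this assay, > 15800 nM, so compound 3 sits at the limit of > 15800 nM in this assay, at which 2 of the 3 values shown sit, and clearly weaker than compound 1. The steps away from compound 1 are both large: an at least 15-fold higher number from compound 1 to compound 2 (1.19 log units; beyond the scatter) and an at least 15-fold higher number from compound 1 to compound 3 (1.19 log units; beyond the scatter); between the two limits, a step that the two limits leave unreadable from compound 2 to compound 3. Compound 4 `CC(=O)c1ccc(NC(=O)CSc2nnc(-c3ccoc3C)n2Cc2ccco2)cc1` carries 4-acetylphenyl in place of 2-methoxyphenyl on an amide-type nitrogen. Within the data shown here, no measured step covers this particular exchange, and compound 2 shows that a single substituent on the anilide ring does not by itself restore the potency of compound 1. Compound 4 is therefore expected to remain close to the limit, an at least 1.0-fold lower number from compound 3 to compound 4 (0.02 log units; that floor lies within the scatter). The estimate for compound 4 is 15000 nM, with a range from 3000 nM to 50000 nM.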

Compound 4, inhibition constant: 2510 nM
The estimate for compound 4 lay 6.0-fold (0.78 log units) above the measured number; measured number below the stated range.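

Working notes: a single substituent on the anilide ring can carry activity in this assay, since 4-acetylphenyl on the amide-type nitrogen gives an at least 6.2-fold lower number from compound 3 to compound 4 (0.79 log units; beyond the scatter). The exchange of fluoro for acetyl on an aromatic carbon gives an at least 6.2-fold lower number from compound 2 to compound 4 (0.79 log units; beyond the scatter), so the second substituent of compound 1 is not required for measurable activity. The 3-chloro-4-fluorophenyl group still keeps a modest edge, with a 2.5-fold higher number from compound 1 to compound 4 (0.40 log units; beyond the scatter).

On these data alone, whether a carboxylic acid or an amine in place of the acetyl would keep this activity remains open. The full size of the two gains also remains open, as the starting points are limits of the assay, not numbers: the limit of > 15800 nM in this assay, at which 2 of the 4 values shown sit.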